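The compounds below may be only part of what the source reports. "The series", "measured", "known", "first", "only" and "open" are said of these compounds alone.

Compound 1 `Nc1ccccc1NC(=O)CCCNCC(=O)Nc1cc(Cl)ccc1Cl` is the starting point. In a functional assay on HCT-116 cells (Homo sapiens) for inhibition, read by MTT assay, with a stated time of 2 days (a higher number here means that more compound is tolerated, a lower number that less compound is tolerated), compound 1 gives only a limit, > 100000 nM. Compound 2 `COc1ccc(NC(=O)CNc2ccc(C(=O)Nc3ccccc3N)cc2)cc1` also gives only a limit in this assay, > 100000 nM. Compound 3 `Nc1ccccc1NC(=O)c1ccc(NCC(=O)Nc2ccc(Cl)cc2)cc1` likewise gives only a limit in this assay, > 100000 nM. Going by the values given here, the single step between measured compounds, a step that the two limits leave unreadable from compound 2 to compound 3, has both ends at limits and cannot be read; the whole of the evidence is the limit of > 100000 nM in this assay, at which 3 of the 3 values shown sit. Compound 4 `Nc1ccccc1NC(=O)CCCNCC(=O)Nc1cccc([N+](=O)[O-])c1` differs from compound 1 by 3-nitrophenyl in place of 2,5-dichlorophenyl on an amide-type nitrogen. Among the compounds with values here, no measured step bears on this change, and the expected step in this assay is a number no higher from compound 1 to compound 4 (the limit leaves the size open), none beyond the scatter. For compound 4 the estimate is 100000 nM, with a range from 40000 nM to 250000 nM, most probably again reported only as a limit.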

Compound 4, concentration lethal to 50% of the cells: > 100000 nM
Compound 4: no number, only a limit; the forecaster's own chance of this, stated with the estimate: 85%; the middle value sits exactly at the limit.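

The step between compound 1 and compound 4 cannot be read, since both ends are limits. The compounds shown leave open which structural change, if any, gives a numerical value in this assay: the limit of > 100000 nM in this assay, at which 4 of the 4 values shown sit.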